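The source may report more compounds than this note shows. Statements on the series, on what has been measured and on what is new or still open speak of the compounds shown alone.

Working notes on the series. For the measured compounds named here, compound 2 `O=C(Nc1c(C(O)(C(F)(F)F)C(F)(F)F)ccc2ccccc12)c1cccc(Cl)c1` holds the lowest of the two numbers so far in an assay on LtK cells with ATP-sensitive inward rectifier potassium channel 11 (Homo sapiens) as the target (a higher number here means that more compound is needed for the effect, a lower number that less compound is needed), where compound 2 gives 98 nM. Its nearest neighbour is compound 1 `CC(C)C(=O)Nc1c(C(O)(C(F)(F)F)C(F)(F)F)ccc2ccccc12`, which in this assay gives 6630 nM; the step of a 68-fold lower number from compound 1 to compound 2 (1.83 log units; beyond the scatter) is the only one measured and is the large one that separates the two.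

Compound 3 `O=C(Nc1c(C(O)(C(F)(F)F)C(F)(F)F)ccc2ccccc12)c1ccc(I)cc1` is the next member; it differs from compound 2 in one place: 4-iodophenyl in place of 3-chlorophenyl on a carbonyl carbon. Going by the values given here, the step from compound 1 to compound 2 swapped an isopropyl for a 3-chlorophenyl on a carbonyl carbon; no measured step compares one halogenated phenyl with another, so that step bears on compound 3 only in that an aromatic ring on the carbonyl carbon remains. Without a direct precedent, no step beyond the scatter is expected; the estimate for compound 3 is 120 nM, range 40 nM to 400 nM, which means an expected step of a 1.2-fold higher number from compound 2 to compound 3 (0.09 log units; within the scatter).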

Compound 3, half-maximal effective concentration: 154 nM
Estimate against measurement, compound 3: 1.3-fold (0.11 log units) below; the range from low to high includes it.
By their numbers in this assay, from the lowest: compounds 2 and 3 (each within the scatter of the next); then compound 1.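

On the carbonyl carbon, this assay gives a 1.6-fold higher number from compound 2 to compound 3 (0.20 log units; within the scatter) for the exchange of 3-chlorophenyl for 4-iodophenyl, so these two halogenated phenyl groups cannot be told apart here. The replacement of isopropyl by 4-iodophenyl gives a 43-fold lower number from compound 1 to compound 3 (1.63 log units; beyond the scatter), which shows that the large step is not confined to 3-chlorophenyl but also holds for a second halogenated phenyl group. Nothing on hand offers an explanation for either step.

Because the halogen and its ring position change together between compound 2 and compound 3, the compounds shown do not separate these two features; 3-iodophenyl or 4-chlorophenyl would do so. They also leave open whether the halogen is needed at all, which unsubstituted phenyl would address, and how a ring carrying an amine or a carboxylic acid would read.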